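Replacing a 4-nitrobenzyl group with a pentyl chain

The compounds below may be only part of what the source reports. "The series", "measured", "known", "first", "only" and "open" are said of these compounds alone.

Measured in a functional assay on IMR-32 cells (Homo sapiens) for antiproliferative activity, read by MTT assay; a higher number here means a weaker inhibitor, a lower number a stronger inhibitor:
- compound 1 `COc1ccc(-n2cc(COc3ccc(/C=C/C(=O)c4ccc5c(c4O)CCC(C)(C)O5)cc3)nn2)c([N+](=O)[O-])c1`: 132000 nM
- compound 2 `CC1(C)CCc2c(ccc(C(=O)/C=C/c3ccc(OCc4cn(Cc5ccc([N+](=O)[O-])cc5)nn4)cc3)c2O)O1`: 17300 nM

Compound 2 has the lower of the two numbers, making it the stronger inhibitor so far. Compound 3 `CCCCCn1cc(COc2ccc(/C=C/C(=O)c3ccc4c(c3O)CCC(C)(C)O4)cc2)nn1` is still unmeasured. It differs from compound 2 at one place: butyl in place of 4-nitrophenyl on a saturated chain carbon bound to an aromatic nitrogen. For the measured compounds named here, one measured step bears on this, a change on that same aromatic nitrogen: a 7.6-fold lower number from compound 1 to compound 2 (0.88 log units; beyond the scatter). That step is modest, and it cannot show the direction for a chain without a ring. A similar or smaller change towards weaker inhibition seems most likely, so an estimated 1.7-fold higher number from compound 2 to compound 3 (0.24 log units; within the scatter) is expected in this assay. The expected value for compound 3 is 30000 nM, with an estimated range of 10000 nM to 90000 nM.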

Compound 3, half-maximal inhibitory concentration: "not active" (no number reported)
Nothing numeric was reported for compound 3, and the estimate cannot be compared.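

In this assay, for the compounds shown here, compound 3 is reported only as not active, with no number, so no step from compound 2 to compound 3 can be read. Nothing available explains this result. These compounds leave open how a pentyl chain truly compares with a 4-nitrobenzyl group.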